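This account rests on a few compounds, and the source may have more. Where it says the series, first, only, none or still open, it means among the compounds named here.

Compound 1 `COc1ccc(N/C(CCNC2=CC(=O)c3ccccc3C2=O)=N\S(=O)(=O)c2ccc(C)cc2)cc1`: 7590 nM
Compound 2 `Cc1ccc(S(=O)(=O)/N=C(/CCNC2=CC(=O)c3ccccc3C2=O)Nc2ccc(Cl)cc2)cc1`: 13400 nM

Of the compounds shown here, two sharing one core have been measured in a functional assay on HeLa cells (Homo sapiens) for cytotoxicity, read by MTT assay, with a stated time of 48 h; a lower number here means a stronger inhibitor, a higher number a weaker inhibitor. Compound 1 gives 7590 nM, and compound 2 gives 13400 nM. Among the compounds with values here, the single step between them, a 1.8-fold higher number from compound 1 to compound 2 (0.25 log units; within the scatter), replaces methoxy with chloro on an aromatic carbon and does not rise above the scatter. Compound 2 thus has the higher of the two numbers, but its distance to compound 1 is not one that the assay can resolve.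

Compound 3 `Cc1ccc(S(=O)(=O)/N=C(/CCNC2=CC(=O)c3ccccc3C2=O)Nc2ccc(F)cc2)cc1` is not yet measured. It differs from compound 2 in one place: fluoro in place of chloro on an aromatic carbon. Within the data shown here, the only step that bears on this change is the one from compound 1 to compound 2, which also swapped a small group at the same position and stayed within the scatter. On that basis the step of a 1.2-fold lower number from compound 2 to compound 3 (0.09 log units; within the scatter) is expected to be small, with no direction beyond the scatter. Compound 3 is therefore estimated at 11000 nM, within a range from 5000 nM to 25000 nM.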

Compound 3, half-maximal inhibitory concentration: 5890 nM
The estimate for compound 3 lay 1.9-fold (0.27 log units) above the measured number; the range from low to high includes it.
By their numbers in this assay, from the lowest: compounds 3, 1 and 2 (each within the scatter of the next, the first and the last beyond it).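

Within the data shown here, the position is more sensitive than the earlier compounds could show: the step of a 2.3-fold lower number from compound 2 to compound 3 (0.36 log units; beyond the scatter) is the first to clear the scatter, although it is modest and chloro and fluoro each count as 1 heavy atom, with no hydrogen-bond donors or acceptors. Fluoro and methoxy, by contrast, are not told apart by the step of a 1.3-fold lower number from compound 1 to compound 3 (0.11 log units; within the scatter), so compound 1 stays within the scatter of both halogen compounds, and only the two ends of the series, compound 2 and compound 3, are resolved. No measurement is available that would account for the difference between chloro and fluoro here.

The compounds shown carry only methoxy, chloro and fluoro on this aromatic carbon, so it remains open how a bromo group, a nitrile, an amine or a carboxylic acid would read there. Also open, from the compounds shown here alone, is whether the fluoro-for-chloro step would hold on another carbon of this ring or alongside a change elsewhere in the shared core.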